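Benzyl variation on the shared core: cytotoxicity working notes

A few compounds are considered here, and "the series" means these few. Any claim that something is new, unique, unknown or untested is made for them only; others in the source may bear on it.

Measured compounds:
compound 1 `CC(C)Nc1ccc(NC(=O)c2cc(Cl)ccc2O)c(Cl)c1`, in an ADME assay on A549 cells (Homo sapiens) for cytotoxicity, read by resazurin assay, with a stated time of 48 h (on this read-out higher numbers stand for lower toxicity in this test and lower numbers for higher toxicity in this test), compound 1 gives 11000 nM
compound 2 `O=C(Nc1ccc(NCc2cccc(C(F)(F)F)c2)cc1Cl)c1cc(Cl)ccc1O`, compound 2 gives 13300 nM
compound 3 `COc1ccc(CNc2ccc(NC(=O)c3cc(Cl)ccc3O)c(Cl)c2)cc1`, compound 3 gives 80700 nM

Compound 3 holds the highest number of the three in this assay, and both steps into it lie beyond the scatter: the nearer is a 6.1-fold higher number from compound 2 to compound 3 (0.78 log units; beyond the scatter), the further a 7.3-fold higher number from compound 1 to compound 3 (0.87 log units; beyond the scatter). Both changes that lead to compound 3 are modest rises, so the shared core tolerates a swap of the group on the ring nitrogen with only moderate shifts in this read-out.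

Compound 4 `O=C(Nc1ccc(NCc2ccc3cn[nH]c3c2)cc1Cl)c1cc(Cl)ccc1O` is not yet measured. Its change from compound 3: 1H-indazol-6-yl in place of 4-methoxyphenyl on a saturated chain carbon bound to a nitrogen on an aromatic ring. Among the measured compounds shown here, of the measured steps, only the one from compound 2 to compound 3 touches the same place, and it was a modest rise when 4-methoxyphenyl replaced 3-(trifluoromethyl)phenyl. For the measured compounds named here, no measured compound carries an indazole, so the direction is uncertain; given that the two aryl variants seen so far differ only modestly, a modest fall back toward the value of compound 2 is expected rather than a large move, and the expected step is a 2.0-fold lower number from compound 3 to compound 4 (0.30 log units; within the scatter). For compound 4 the estimate in this assay is 40000 nM, with a range from 12000 nM to 130000 nM.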

Compound 4, half-maximal cytotoxic concentration: 45300 nM
The estimate for compound 4 lay 1.1-fold (0.05 log units) below the measured number; low and high end bracket the measured number.
By their numbers in this assay, from the lowest: compounds 1 and 2 (each within the scatter of the next); then compounds 4 and 3 (each within the scatter of the next).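

In this assay, the place on the saturated chain carbon bound to a nitrogen on an aromatic ring takes 1H-indazol-6-yl, with its added five-membered aromatic ring and hydrogen-bond donor, and compound 4 cannot be told apart from compound 3 (a 1.8-fold lower number from compound 3 to compound 4 (0.25 log units; within the scatter)). The step from the trifluoromethyl variant is beyond the scatter (a 3.4-fold higher number from compound 2 to compound 4 (0.53 log units; beyond the scatter)), so among the three aryl groups seen at this place, 3-(trifluoromethyl)phenyl in compound 2 stands apart, while 4-methoxyphenyl and 1H-indazol-6-yl share one level despite their different ring make-up. Nothing available gives a cause for either step.

Compound 4 alone cannot separate the contribution of the added five-membered ring from that of its hydrogen-bond donor, and the compounds shown do not settle which feature, if either, governs the number in this assay. Also open, going by these compounds, is whether this level holds with a carboxylic acid or an amine on the aryl group, or with a longer chain between the ring nitrogen and that aryl group.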